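The source may report more compounds than this note shows. Statements on the series, on what has been measured and on what is new or still open speak of the compounds shown alone.

For the measured compounds named here, compound 2 `COC(=O)c1nc(C2CC2)n(-c2ccc(F)cc2)n1` carries the only measured number in this set: in a functional assay on Jurkat cells (Homo sapiens) for inhibition, read by MTT assay, with a stated time of 72 h (on this read-out lower numbers stand for stronger inhibition of growth and higher numbers for weaker inhibition of growth), compound 2 gives 9420 nM. Compound 1 `COC(=O)c1nc(C)n(-c2ccccc2C(F)(F)F)n1` gives > 100000 nM in this assay, which is a limit and not a number. Compound 3 `COC(=O)c1nc(-c2ccc[nH]2)n(-c2ccc(F)cc2)n1` differs from compound 2 by 1H-pyrrol-2-yl in place of cyclopropyl on an aromatic carbon. Going by the values given here, no measured pair shows what such a change does, so the direction is open; a modest gain beyond the scatter seems plausible, though a step of either sign or none would also fit. Compound 3 is therefore expected at 5000 nM, within 1000 nM to 30000 nM, an estimated step of a 1.9-fold lower number from compound 2 to compound 3 (0.28 log units; within the scatter).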

Compound 3, concentration for 50% growth inhibition: 9010 nM
The estimate for compound 3 lay 1.8-fold (0.26 log units) below the measured number; measured number inside the range.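

For the compounds shown here, the first comparison at this position, read in this assay and exchanging cyclopropyl for 1H-pyrrol-2-yl, shows a 1.0-fold lower number from compound 2 to compound 3 (0.02 log units; within the scatter) and so no real change. On this read-out, a larger ring that is aromatic and brings a hydrogen-bond donor therefore costs nothing measurable here. Nothing shown explains this outcome.

From the compounds shown here alone, whether an amine, a carboxylic acid or a longer alkyl chain at this position would shift the number stays open. What replacing the methoxycarbonyl group, shared by every compound shown, would do is also open.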